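Swapping Nitrile for Carboxylic Acid in a Kinase Inhibitor Series

The compounds below may be only part of what the source reports. "The series", "measured", "known", "first", "only" and "open" are said of these compounds alone.

Measured compounds:
compound 1: `COc1ccc(OCC(=O)Nc2cccc(NC(=O)c3ccc(N(C)C)cc3)c2)cc1F`, 1820 nM
compound 2: `Cc1c(OCC(=O)Nc2cccc(NC(=O)c3ccc(N(C)C)cc3)c2)ccc2c(=O)ccoc12`, a limit of the assay, > 10000 nM
compound 3: `N#Cc1ccc(C(=O)Nc2cccc(NC(=O)COc3ccc4c(=O)ccoc4c3)c2)cc1`, 123 nM

In an assay on isolated protein for inhibition of Rho-associated protein kinase 1 (Homo sapiens), read by scintillation counting, radiometric assay and 33P incorporation, with a stated time of 40 min, in the presence of a further agent that is not named here (a lower number here means a stronger inhibitor, a higher number a weaker inhibitor), compound 3 gives the lowest of the two numbers, and compound 1 sits well above it, beyond the usual scatter. For compound 2 only a limit was recorded, (the limit of > 10000 nM in this assay, at which 1 of the 3 values shown sits).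

Compound 4, `O=C(COc1ccc2c(=O)ccoc2c1)Nc1cccc(NC(=O)c2ccc(C(=O)O)cc2)c1`, differs from compound 3 in one place: carboxy in place of cyano on an aromatic carbon. For the measured compounds named here, no measured pair shows this exact change, so the expectation rests on compound 3 alone. The step from compound 3 to compound 4 is expected to weaken binding, with a 4.9-fold higher number from compound 3 to compound 4 (0.69 log units; beyond the scatter). Compound 4 is therefore estimated at 600 nM, within a range from 150 nM to 3000 nM.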

Compound 4, half-maximal inhibitory concentration: 6890 nM
Compound 4: the middle estimate sits 11-fold (1.06 log units) below what was measured; measured number outside the range, above it.
By their numbers in this assay, from the lowest: compound 3; then compound 1; then compound 4. At a limit, above all of these: compound 2.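

At this position on the aromatic ring, the group carried matters greatly: carboxy in place of cyano gives a 56-fold higher number from compound 3 to compound 4 (1.75 log units; beyond the scatter). For the compounds shown here, the earlier compounds offered no pair that isolated a single change here, so this is the first direct reading of the position. Nothing measured here explains the loss.

Going by these compounds, whether a primary amide or a methyl ester in the same place would read closer to compound 3 or to compound 4 remains open. So does whether the same swap would have a similar effect in the other compounds.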